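Returning a pyridinylmethyl arm to the amine of compound 2

The source may report more compounds than this note shows. Statements on the series, on what has been measured and on what is new or still open speak of the compounds shown alone.

Compound 2 `NS(=O)(=O)Oc1ccc2c(c1)CN(C(=O)c1ccc(N3CCCCC3)cc1)CC2` was tested in an assay on HEK293 cells for inhibition of Steryl-sulfatase (Homo sapiens), tested at 1 uM (a higher number here means a stronger effect of the compound at the concentration tested, a lower number a weaker effect), and gives 38.3%. Within the data shown here, this is the lower of the two numbers measured so far; the only other compound, compound 1 `CCN(Cc1cccnc1)c1ccc(C(=O)N2CCc3ccc(OS(N)(=O)=O)cc3C2)cc1`, gives 85.2% in this assay. Among the measured compounds shown here, the single measured step links these two: a number 46.9 percentage points lower from compound 1 to compound 2 (beyond the scatter). Compound 3 `CCN(Cc1ccncc1)c1ccc(C(=O)N2CCc3ccc(OS(N)(=O)=O)cc3C2)cc1` is not yet measured. It differs from compound 2 in one place: ethyl((pyridin-4-yl)methyl)amino in place of piperidin-1-yl on an aromatic carbon. The measured step bears directly on this change, since exchanging ethyl((pyridin-3-yl)methyl)amino for piperidin-1-yl cost a large amount of inhibition; compound 3 makes the reverse kind of exchange, with pyridin-4-yl in place of pyridin-3-yl on the methyl arm. A large rise in this assay is therefore expected. For compound 3 the estimated value is 78% (range 55% to 95%), an expected step of a number 39.7 percentage points higher from compound 2 to compound 3 (beyond the scatter) because of a number 46.9 percentage points lower from compound 1 to compound 2 (beyond the scatter).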

Compound 3, a percentage reported as inhibition, at one concentration (the size of the read-out at that concentration, not a potency) in the Steryl-sulfatase assay: 86.6%
Compound 3: the middle estimate sits 8.6 percentage points below what was measured; measured number inside the range.
By their numbers in the Steryl-sulfatase assay, from the lowest: compound 2; then compounds 1 and 3 (each within the scatter of the next).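

In the Steryl-sulfatase assay compound 2 gives 38.3% and compound 3 gives 86.6%: ethyl((pyridin-4-yl)methyl)amino in place of piperidin-1-yl on an aromatic carbon gives a large gain (a number 48.3 percentage points higher from compound 2 to compound 3 (beyond the scatter)), so the advantage over piperidin-1-yl is not confined to the pyridin-3-yl arm of compound 1. Pyridin-4-yl in place of pyridin-3-yl gives a step that cannot be told from noise (a number 1.4 percentage points higher from compound 1 to compound 3 (within the scatter)), so in this read-out the two arms cannot be separated. The large step in inhibition comes with no change in a physicochemical assay for lipophilicity; on this read-out higher numbers stand for higher lipophilicity and lower numbers for lower lipophilicity (no change at the digits printed from compound 2 to compound 3 (within the scatter)), where compound 2 gives 1.93 and compound 3 gives 1.93, but nothing available explains the gain.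

The compounds shown do not separate the part played by the ethyl group from that of the pyridinylmethyl arm, and a pyridin-2-yl or plain phenyl ring on that arm remains open. Each number also comes from a single concentration, so it does not rank compound 1 and compound 3 by potency.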